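The compounds below may be only part of what the source reports. "The series", "measured", "known", "first", "only" and "open" are said of these compounds alone.

Compound 1 `CCCCOc1ccc(C(=O)NC2CCCCC2)cn1`: 2510 nM; 2490 nM (2 entries)
Compound 2 `CCCOc1ccc(C(=O)NC2CCCCC2)cn1`: "not active" (no number reported)

Two measured compounds share a core and differ only in the alkoxy chain on it. In a functional assay on HEK293 cells for positive allosteric modulation of metabotropic glutamate receptor 5 (Rattus norvegicus), read by calcium flux (a lower number here means that less compound is needed, a higher number that more compound is needed for the effect), compound 1 gives 2510 nM; 2490 nM (2 entries), and the two entries agree closely (the several entries of compound 1 in this assay, 2510 nM; 2490 nM (2 entries)). Compound 2 gives "not active" (no number reported) in this assay, and a second entry for compound 2 likewise carries no number, so compound 2 stands without a measured concentration on which a step could be built.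

Compound 3 `O=C(NC1CCCCC1)c1ccc(OCC2CC2)nc1` is the next compound and is not yet measured. It differs from compound 2 by cyclopropyl in place of ethyl on a saturated chain carbon bound to an oxygen on an aromatic ring. Going by the values given here, since compound 2 has no number in this assay, no step from compound 2 to compound 3 can be computed; a step in the direction of activity, with a number appearing where compound 2 had none, is what is expected, though the size of it cannot be stated from these two compounds alone. An estimate for compound 3 is drawn instead from compound 1, because compound 1 gives 2510 nM; 2490 nM (2 entries) with a chain of comparable length. Compound 3 is expected to give about 3000 nM in this assay, with a range of 700 nM to 15000 nM, and a real chance that it too is reported only as not active.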

Compound 3, half-maximal effective concentration: "not active" (no number reported)
Nothing numeric was reported for compound 3, so the estimate cannot be set against anything.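

In this assay, going by these compounds alone, compound 3 is reported as not active without a number, as compound 2 is, so no step from compound 2 to compound 3 can be read. The compounds shown leave open whether the change from propoxy to cyclopropylmethoxy alters the response at all: neither side of that change carries a concentration.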